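This account rests on a few compounds, and the source may have more. Where it says the series, first, only, none or still open, it means among the compounds named here.

In an ADME assay on MCF-10A cells (Homo sapiens) for inhibition, with a stated time of 48 h (a lower number here means a stronger inhibitor, a higher number a weaker inhibitor), the measured compounds stand as follows:

- compound 1 `O=C(Nc1ccc(C(F)(F)F)cc1)N1CCC[C@H]1c1nc(-c2ccccc2)no1` gives > 50000 nM, which is a limit of the assay rather than a number.
- compound 2 `O=C(Nc1ccc([N+](=O)[O-])cc1)N1CCC[C@H]1c1nc(-c2ccccc2)no1` gives > 50000 nM, again a limit.
- compound 3 `O=C(Nc1ccc(Cl)cc1)N1CCC[C@H]1c1nc(-c2cccc(F)c2)no1` gives > 50000 nM, likewise a limit.

Compound 3 therefore stands where everything measured so far stands: at the limit, with no number of its own to place it against the others, as all values sit together at the limit of > 50000 nM in this assay, at which 3 of the 3 values shown sit.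

Compound 4 `N#Cc1ccc(-c2noc([C@@H]3CCCN3C(=O)Nc3ccc(Cl)cc3)n2)cc1` is the next compound and differs from compound 3 at one place: 4-cyanophenyl in place of 3-fluorophenyl on an aromatic carbon.

Among the compounds with values here, the only step measured between two compounds is a step that the two limits leave unreadable from compound 1 to compound 2, and it is unreadable, since both ends are limits. It also concerns a different place, the group on the ring carried by the urea, not the group on the five-membered aromatic ring that is changed here. So no measured step bears on the change from compound 3 to compound 4, and none shows any direction.

Compound 4 is therefore expected to give 80000 nM, in a range from 25000 nM to 300000 nM. The step that the limit leaves unreadable from compound 3 to compound 4 is expected to stay within the scatter, with a limit again the most likely outcome.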

Compound 4, half-maximal inhibitory concentration: > 50000 nM
Compound 4 gave a limit, no number; the forecaster's own chance of this, stated with the estimate: 85%; the middle value does not contradict the limit.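

In this assay the change from compound 3 to compound 4 cannot be read as a step, since both compounds give a limit rather than a number: the limit of > 50000 nM in this assay, at which 4 of the 4 values shown sit. The compounds shown leave open whether any group on the shared core can bring a readable value in this assay, and so how these groups compare with one another.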